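A few compounds are considered here, and "the series" means these few. Any claim that something is new, unique, unknown or untested is made for them only; others in the source may bear on it.

Measured so far:
Compound 1, `CCCCCCCCOc1nc(N)nc2c1ncn2/C=C1/CC1(CO)CO`: in an ADME assay on BCBL1 cells (Homo sapiens) for cytotoxicity, with a stated time of 7 days (a lower number here means that less compound is tolerated, a higher number that more compound is tolerated), compound 1 gives > 20000 nM, which is a limit of the assay.
Compound 2, `CCCNc1nc(N)nc2c1ncn2/C=C1/CC1(CO)CO`: in this assay compound 2 gives > 20000 nM, again a limit.
Compound 3, `CCCCNc1nc(N)nc2c1ncn2/C=C1/CC1(CO)CO`: in this assay compound 3 gives > 20000 nM, also a limit.

Compound 2 therefore stands at the limit, as do the other two: the limit of > 20000 nM in this assay, at which 3 of the 3 values shown sit. The measured steps that touch the same position, a step that the two limits leave unreadable from compound 1 to compound 2, a step that the two limits leave unreadable from compound 1 to compound 3 and a step that the two limits leave unreadable from compound 2 to compound 3, all run between limits, so none of them has a readable size. Compound 4, `CCCCCCSc1nc(N)nc2c1ncn2/C=C1/CC1(CO)CO`, differs from compound 2 by hexylsulfanyl in place of propylamino on an aromatic carbon. With every neighbouring step unreadable, the expected step of a number no higher from compound 2 to compound 4 (the limit leaves the size open) cannot be sized from them, and compound 4 is expected to remain at the limit. Compound 4 is accordingly estimated at 20000 nM, within 10000 nM to 40000 nM.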

Compound 4, half-maximal cytotoxic concentration: > 20000 nM
Compound 4 gave a limit, no number (the forecaster's own chance of this, stated with the estimate: 85%); the middle value sits exactly at the limit.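

Compound 4 sits at a limit in this assay, like compound 1, compound 2 and compound 3, so none of its steps to them can be read. The compounds shown leave open at what concentration any of them becomes cytotoxic.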